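Methyl in place of methoxy, second occurrence in the series

This account rests on a few compounds, and the source may have more. Where it says the series, first, only, none or still open, it means among the compounds named here.

Measured so far:
compound 1, `Cc1ccc(OCCCCOc2ccc(C(=O)CC(C)(C)C)c(O)c2C)cc1C(=O)O`, in an assay for positive allosteric modulation of metabotropic glutamate receptor 3 (Rattus norvegicus) (a higher number here means that more compound is needed for the effect, a lower number that less compound is needed), compound 1 gives 309 nM.
compound 2, `COc1ccc(OCCCCOc2ccc(C(=O)CC(C)(C)C)c(O)c2C)cc1C(=O)O`, in this assay compound 2 gives 490 nM.
compound 3, `COc1cc(C(=O)O)ccc1OC[C@H](C)COc1ccc(C(=O)CC(C)(C)C)c(O)c1C`, in this assay compound 3 gives 512 nM.

Compounds 2 and 3 share their atoms but join them differently; the difference between the two cores is not broken down here. Their two numbers in this assay are within the scatter of each other, as are all three measured values.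

Compound 4, `Cc1cc(C(=O)O)ccc1OC[C@H](C)COc1ccc(C(=O)CC(C)(C)C)c(O)c1C`, has not been measured. It differs from compound 3 by methyl in place of methoxy on an aromatic carbon. The same kind of change separates compounds 2 and 1: methyl in place of methoxy on an aromatic carbon. The surroundings of the place are not the same word for word, however: in the measured pair the methyl sits ortho to a carboxy group and para to a large group, whereas in compound 4 it sits ortho to a large group and meta to a carboxy group. So the two changes are the same kind of change, not the same.

The measured step of this kind was a 1.6-fold lower number from compound 2 to compound 1 (0.20 log units; within the scatter). On that basis compound 4 is expected to sit near compound 3, with an estimated step of a 1.3-fold lower number from compound 3 to compound 4 (0.13 log units; within the scatter), resting on the step from compound 2 to compound 1 being within the scatter and on the place differing as described. The estimate for compound 4 in this assay is 380 nM, expected to fall between 180 nM and 800 nM.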

Compound 4, half-maximal effective concentration: 1520 nM
For compound 4 the middle estimate is 4.0-fold (0.60 log units) below the measured one, and the stated range ends below it.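

In this assay, methyl in place of methoxy does not transfer as one fixed step between these two cores: the same change on two cores in this assay, a 1.6-fold lower number (0.20 log units; within the scatter) from compound 2 to compound 1 and a 3.0-fold higher number (0.47 log units; beyond the scatter) from compound 3 to compound 4, 4.7-fold (0.67 log units) apart, beyond the scatter of two such steps.

The new step is a 3.0-fold higher number from compound 3 to compound 4 (0.47 log units; beyond the scatter), with the methyl ortho to a large group and meta to a carboxy group, so the pair of compound 2 and compound 1 gives no reliable guide to the size or direction of the change on the core of compound 3. What this does not show is which difference between the two pairs matters, since the cores differ in their linking chain and the exchanged groups also stand at different places relative to the carboxy group; with one pair on each core, these two differences cannot be separated, and no general rule for the series follows.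

Still open, as far as these compounds go, is whether the split follows the linking chain or the place of the exchanged group, which would take a methoxy and methyl pair that differs in only one of these. Also open, from the compounds shown here alone, is how other groups at this place, such as chloro, ethyl or hydroxy, would read in this assay on either core.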